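This account rests on a few compounds, and the source may have more. Where it says the series, first, only, none or still open, it means among the compounds named here.

Among the measured compounds shown here, in a functional assay on MIA PaCa-2 cells (Homo sapiens) for cytotoxicity, read by fluorescence, with a stated time of 48 h (a higher number here means that more compound is needed for the effect, a lower number that less compound is needed), compound 1 `CC(C)=CCC/C(C)=C/CC/C(C)=C/CSC[C@H](NC(=O)CCCCCN1CCN(C)CC1)C(=O)NC1CCCCCC1` gives 2700 nM, the only true number so far. Compound 2 `CC(C)=CCC/C(C)=C/CC/C(C)=C/CSc1ccccc1C(N)=O` returns only a limit, > 20000 nM. For the measured compounds named here, that limit offers no second number for comparison, and no two measured compounds differ in one place, so the series has no measured step to draw on.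

Compound 3 `CC(C)=CCC/C(C)=C/CC/C(C)=C/CSC[C@H](NC(=O)CCCCCN1CCN(C)CC1)C(=O)NC1CCCCC1` keeps the core of compound 1 and changes one group: cyclohexyl in place of cycloheptyl on an amide-type nitrogen. In words, this is cyclohexyl in place of cycloheptyl on an amide-type nitrogen. The rest of the structure stays the same, and the value of compound 1, 2700 nM, is the only anchor. In this assay the expected change is none beyond the scatter, with no firm direction. The estimated step of a 1.1-fold higher number from compound 1 to compound 3 (0.05 log units; within the scatter) is therefore expected to be small. Compound 3 is estimated at 3000 nM, with an expected range of 1500 nM to 6500 nM.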

Compound 3, half-maximal effective concentration: 5900 nM
Estimate against measurement, compound 3: 2.0-fold (0.29 log units) below; the measured number falls inside the stated range.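

In this assay, among the compounds shown here, the amide-type nitrogen is the first position with a measured step: cyclohexyl in place of cycloheptyl gives a 2.2-fold higher number from compound 1 to compound 3 (0.34 log units; beyond the scatter). For the compounds shown here, this ring is therefore not a silent part of the structure: with the rest of the core of compound 1 held constant, a change of ring size alone moves the number modestly, and the cycloheptyl compound is the one needing less compound. No measured property at hand bears on this step.

A single step gives a direction between two rings, not a trend with ring size. On these data alone, whether cyclopentyl or phenyl on the same nitrogen would continue, reverse or flatten that direction remains open.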